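The source may hold more compounds than are shown below. What is called first, only, known or untested is meant among the compounds shown, and "the series" means these compounds.

Compound 2 `CN1CCN(c2ccc(Nc3ncc(/N=C/c4ccccc4)c(NC4CCCC4)n3)cc2)CC1` is the point of departure. In a functional assay on HCT-116 cells (Homo sapiens) for antiproliferative activity, read by MTT assay (on this read-out lower numbers stand for stronger inhibition and higher numbers for weaker inhibition), compound 2 gives 35200 nM, the highest of three numbers, though its gap to compound 3 stays within the scatter. Compound 3 `CN1CCN(c2ccc(Nc3ncc(/N=C/c4cccs4)c(NC4CCCC4)n3)cc2)CC1` gives 18900 nM, and compound 1 `CCOC(=O)/C=N/c1cnc(Nc2ccc(N3CCN(C)CC3)cc2)nc1NC1CCCC1` gives 17000 nM. The measured steps all swap the group on the carbon with a double bond to nitrogen: a 2.1-fold higher number from compound 1 to compound 2 (0.32 log units; beyond the scatter), a 1.1-fold higher number from compound 1 to compound 3 (0.05 log units; within the scatter), and a 1.9-fold lower number from compound 2 to compound 3 (0.27 log units; within the scatter). Compound 4 `CN1CCN(c2ccc(Nc3ncc(/N=C/c4ccc(C(F)(F)F)cc4)c(NC4CCCC4)n3)cc2)CC1` keeps the phenyl of compound 2 and adds to it: trifluoromethyl in place of hydrogen on an aromatic carbon. Among the compounds with values here, no measured step touches this phenyl, so the three steps bear on it only loosely, by showing that changes at this end of the molecule moved the numbers modestly at most. A change of similar or smaller size is therefore expected, with no clear direction. Compound 4 is estimated at 28000 nM, within 10000 nM to 70000 nM, an expected step of a 1.3-fold lower number from compound 2 to compound 4 (0.10 log units; within the scatter).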

Compound 4, half-maximal inhibitory concentration: > 100000 nM
Compound 4: no number, only a limit; the forecaster's own chance of this, stated with the estimate: 10%; middle value at least 3.5-fold (0.55 log units) away from the limit.
By their numbers in this assay, from the lowest: compounds 1, 3 and 2 (each within the scatter of the next, the first and the last beyond it). At a limit, above all of these: compound 4.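

Compound 4 has no true number here, only a limit of the assay: the limit of > 100000 nM in this assay, at which 1 of the 4 values shown sits. Swapping the whole group on the carbon with a double bond to nitrogen had changed the numbers only modestly, but this first substitution on the phenyl itself, para to a large group, gives an at least 2.8-fold higher number from compound 2 to compound 4 (0.45 log units; beyond the scatter), which shows that this ring position is sensitive to change and that here the change weakens inhibition. Compound 4 is also the weakest of the four, with an at least 5.2-fold higher number from compound 3 to compound 4 (0.72 log units; beyond the scatter) and an at least 5.8-fold higher number from compound 1 to compound 4 (0.76 log units; beyond the scatter).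

As far as these compounds go, how far past the limit the true value lies remains open, so the full size of these steps is unknown. Also open, from the compounds shown here alone, is whether a methyl, a methoxy or an amine in the same place on the phenyl would shift the number the same way as trifluoromethyl.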